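The source may report more compounds than this note shows. Statements on the series, on what has been measured and on what is new or still open speak of the compounds shown alone.

Compound 1 `CC1=C(C(=O)C2CC2)C(c2ccsc2)NC(=O)N1` opens the series. In an assay on membranes from HeLa cells for displacement of a labelled ligand from adenosine receptor A3 (Homo sapiens), read by scintillation counting, with a stated time of 180 min, tested at 1 uM (on this read-out lower numbers stand for less inhibition and higher numbers for more inhibition at the one concentration tested (going by the name of the read-out)), compound 1 gives 1%. Compound 2 `CC1=C(C(=O)SC(C)C)C(c2ccsc2)NC(=O)N1` carries isopropylsulfanyl in place of cyclopropyl on a carbonyl carbon, and in this assay compound 2 gives 1%. Among the measured compounds shown here, the only step measured so far is no change at the digits printed from compound 1 to compound 2 (within the scatter). Compound 2 therefore stands level with compound 1 at the digits shown, and compound 1 is its nearest neighbour. Compound 3 `CC1=C(c2ncc(C)o2)C(c2ccsc2)NC(=O)N1` differs from compound 2 in this way: 5-methyl-1,3-oxazol-2-yl in place of (isopropylsulfanyl)carbonyl on a double-bonded ring carbon. For the measured compounds named here, the one step that bears on the change, no change at the digits printed from compound 1 to compound 2 (within the scatter), exchanged the group on the double-bonded ring carbon without moving the read-out, so no step beyond the scatter is expected here either, in either direction. The step is estimated as a number 2 percentage points higher from compound 2 to compound 3 (within the scatter). Compound 3 is accordingly expected to give 3%, within a range from 0% to 15%.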

Compound 3, a percentage reported as inhibition, at one concentration (the size of the read-out at that concentration, not a potency): 2%
Beside the measured number, compound 3's estimate is 1 percentage points above it; the measured number falls inside the stated range.
By their numbers in this assay, from the lowest: compounds 1, 2 and 3 (each within the scatter of the next).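

Among the compounds shown here, the earlier pair exchanged only one carbonyl-linked group for another, whereas here the carbonyl itself leaves the double-bonded ring carbon and a five-membered aromatic ring with 2 hetero atoms takes its place. Even so, this assay gives a number 1 percentage points higher from compound 2 to compound 3 (within the scatter) and a number 1 percentage points higher from compound 1 to compound 3 (within the scatter), so neither the thioester-type (isopropylsulfanyl)carbonyl group, nor cyclopropylcarbonyl, nor 5-methyl-1,3-oxazol-2-yl separates from the others at the one concentration tested. Nothing available explains this result.

The compounds shown leave open whether any group on this ring carbon, such as an amine or a carboxylic acid, would move the read-out beyond the scatter. They also leave open whether replacing the thiophen-3-yl group, which all three compounds share, would do so.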